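This account rests on a few compounds, and the source may have more. Where it says the series, first, only, none or still open, it means among the compounds named here.

The compounds share a core with a carbonyl-bearing side chain and a linker to a carboxyphenyl group. Compound 1 `Cc1c(OCCCCOc2ccc(C(=O)O)cc2)ccc(C(=O)CC(C)C)c1O` carries an isopropyl group on the saturated chain carbon bound to the carbonyl carbon; in an assay on HEK293 cells for positive allosteric modulation of metabotropic glutamate receptor 3 (Rattus norvegicus), read by thallium flux, with a stated time of 2.5 min (on this read-out lower numbers stand for an effect already at smaller amounts and higher numbers for an effect only at larger amounts of compound), compound 1 gives 2720 nM. Compound 2 `Cc1c(OCCCCOc2ccc(C(=O)O)cc2)ccc(C(=O)CC2CCCC2)c1O` has cyclopentyl in place of isopropyl there. In this assay compound 2 gives only a limit, > 10000 nM, and no number. The measured step of an at least 3.6-fold higher number from compound 1 to compound 2 (0.56 log units; beyond the scatter) thus runs to a limit of the assay (the limit of > 10000 nM in this assay, at which 1 of the 3 values shown sits). Compound 3 `COC(=O)c1ccc(OCCCCOc2ccc(C(=O)CC3CCCC3)c(C)c2C)cc1` is the methyl ester with no hydroxyl on the core; in this assay compound 3 has the entry "not determined" (no result reported), so no result was reported for it.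

Compound 4 `Cc1c(OCCCCOc2cccc(C(=O)O)c2)ccc(C(=O)CC2CCCC2)c1O` is the next compound: 3-carboxyphenyl in place of 4-carboxyphenyl on an oxygen on a saturated carbon. Among the compounds with values here, none of the measured steps touches the carboxyphenyl end of the linker, so no measured step bears on this change. Compound 2 already sits at the limit, and for compound 4 the step that the limit leaves unreadable from compound 2 to compound 4 is expected to stay there. Compound 4 is therefore estimated at 15000 nM, within 4000 nM to 60000 nM.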

Compound 4, half-maximal effective concentration: 3400 nM
Compound 4: the middle estimate sits 4.4-fold (0.64 log units) above what was measured; the measured number lies below the stated range.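

Within the data shown here, until now, the only step that could be read lay on the carbonyl side chain, and both compounds in it carried 4-carboxyphenyl. This result shows that the other end of the molecule also matters in this assay: with the same atoms joined differently, 3-carboxyphenyl in place of 4-carboxyphenyl gives an at least 2.9-fold lower number from compound 2 to compound 4 (0.46 log units; beyond the scatter), so cyclopentyl on the side chain does not by itself hold a compound at the limit. The true size of this step remains unknown because the entry for compound 2 is a limit and not a number: the limit of > 10000 nM in this assay, at which 1 of the 4 values shown sits.

The compounds shown do not tell whether 3-carboxyphenyl would lower the number in the same way with isopropyl on the side chain. They also leave open what an amide in place of the carboxylic acid, or a longer chain in the linker, would do at this end.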